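Methoxy for Dimethylamino on a Nucleoside Core at the Limit

A few compounds are considered here, and "the series" means these few. Any claim that something is new, unique, unknown or untested is made for them only; others in the source may bear on it.

Compound 1 `Cc1ncnc2c1c(-c1cc3ccccc3o1)cn2[C@@H]1O[C@H](CO)[C@@H](O)[C@H]1O`: > 20000 nM
Compound 2 `COc1ncnc2c1c(-c1ccccc1)cn2[C@@H]1O[C@H](CO)[C@@H](O)[C@H]1O`: > 20000 nM
Compound 3 `CN(C)c1ncnc2c1c(-c1cc3ccccc3o1)cn2[C@@H]1O[C@H](CO)[C@@H](O)[C@H]1O`: > 20000 nM

Of the compounds shown here, three have been tested in a functional assay on HeLa S3 cells (Homo sapiens) for antiproliferative activity, read by XTT assay, with a stated time of 72 h; on this read-out lower numbers stand for stronger inhibition and higher numbers for weaker inhibition. For compound 1 the value is a limit of the assay and not a number. The same holds for compound 2, whose value is also a limit. Compound 3 likewise sits at a limit, so no number is known for it. All three values rest at the limit of > 20000 nM in this assay, at which 3 of the 3 values shown sit. For the measured compounds named here, the only single-point step among them, a step that the two limits leave unreadable from compound 1 to compound 3, cannot be read: both of its ends are limits.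

The next compound, compound 4 `COc1ncnc2c1c(-c1cc3ccccc3o1)cn2[C@@H]1O[C@H](CO)[C@@H](O)[C@H]1O`, differs from compound 3 by methoxy in place of dimethylamino on an aromatic carbon. Compound 2 carries this same methoxy group on a core that differs from compound 4 elsewhere, and it too sits at a limit. Going by the values given here, with the step from compound 1 to compound 3 unreadable and every value shown at the limit, no measured step tells the size or direction of change to expect in this assay. Compound 4 is therefore expected to stay at the limit as well, with an estimated value of 30000 nM (range 10000 nM to 100000 nM). That estimate means an expected step that the limit leaves unreadable from compound 3 to compound 4.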

Compound 4, half-maximal inhibitory concentration: 9240 nM
Compound 4: middle estimate off by 3.2-fold (0.51 log units), on the high side; measured number outside the range, below it.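

For the compounds shown here, compound 4 is the only compound here with a real number in this assay, and it shows that the group on this aromatic carbon, next to the ring nitrogen, can move the read-out: methoxy in place of dimethylamino gives an at least 2.1-fold lower number from compound 3 to compound 4 (0.33 log units; beyond the scatter), and methoxy in place of methyl gives an at least 2.1-fold lower number from compound 1 to compound 4 (0.33 log units; beyond the scatter). Methoxy does not do this alone, since 1-benzofuran-2-yl in place of phenyl on another aromatic carbon gives an at least 2.1-fold lower number from compound 2 to compound 4 (0.33 log units; beyond the scatter), so among these compounds the measurable inhibition appears only when the two groups occur together. Each of these steps gives only a minimum size, because one end of each is a limit and not a number: the limit of > 20000 nM in this assay, at which 3 of the 4 values shown sit.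

From the compounds shown here alone, the true sizes of these steps remain unknown, and the earlier step between the two compounds at the limit cannot be read. Going by these compounds, it also remains open whether an ethoxy group, a chlorine atom or a primary amine at the methoxy position would lower the number further or return it to the limit.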